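A few compounds are considered here, and "the series" means these few. Any claim that something is new, unique, unknown or untested is made for them only; others in the source may bear on it.

Compound 1 `C=C/C=C\[C@H](C)[C@H](OC(N)=O)[C@@H](C)[C@H](O)[C@@H](C)C/C(C)=C\[C@H](C)[C@@H](O)[C@@H](C)/C=C\[C@@H](O)C[C@@H]1OC(=O)[C@H](C)[C@@H](O[Si](C)(C)C(C)(C)C)[C@H]1C`: 2650 nM
Compound 2 `C=C/C=C\[C@H](C)[C@H](OC(N)=O)[C@@H](C)[C@H](O)[C@@H](C)CC(=C)[C@H]1[C@H](C)[C@@H](O)[C@@H](C)[C@@H]1/C=C/C[C@@H]1OC(=O)[C@H](C)[C@@H](O)[C@H]1C`: 330 nM
Compound 3 `C=C/C=C\[C@H](C)[C@H](OC(N)=O)[C@@H](C)[C@H](O)[C@@H](C)C[C@@](C)(O)[C@H]1[C@H](C)[C@@H](O)[C@@H](C)[C@@H]1/C=C/C[C@@H]1OC(=O)[C@H](C)[C@@H](O)[C@H]1C`: 3030 nM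

In a functional assay on PANC-1 cells (Homo sapiens) for cytotoxicity (on this read-out higher numbers stand for weaker inhibition and lower numbers for stronger inhibition), compound 3 gives 3030 nM, which lies within the usual scatter of compound 1 at 2650 nM. Compound 2 gives 330 nM, a lower number than compound 3 by a margin beyond the scatter, so compound 3 sits on the weaker side of this small set.

The next molecule is compound 4 `C=C/C=C\[C@H](C)[C@H](OC(N)=O)[C@@H](C)[C@H](O)[C@H](C)C[C@](C)(O)[C@H]1[C@H](C)[C@@H](O)[C@@H](C)[C@@H]1/C=C/C[C@@H]1OC(=O)[C@H](C)[C@@H](O)[C@H]1C`. It has the same atoms and bonds as compound 3 and differs only in its three-dimensional arrangement: the two compounds have the same atoms and bonds and differ only in configuration as drawn: 2 of 17 stereo elements differ; a stereocentre at a saturated chain carbon is drawn S in compound 3 and R in compound 4; a stereocentre at a saturated chain carbon is drawn R in compound 3 and S in compound 4. Within the data shown here, no measured pair here isolates a change of this kind, so the data give no direct guide to its effect. The expectation in this assay is therefore a small shift toward weaker inhibition, with no step beyond the scatter as the likeliest outcome. The estimated step is a 1.5-fold higher number from compound 3 to compound 4 (0.17 log units; within the scatter). For compound 4 the estimated value is 4500 nM. The expected range runs from 1500 nM to 13000 nM.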

Compound 4, half-maximal inhibitory concentration: > 5000 nM
Compound 4 was reported as a limit (the forecaster's own chance of this, stated with the estimate: 10%); middle value at least 1.1-fold (0.04 log units) from the limit.
By their numbers in this assay, from the lowest: compound 2; then compounds 1 and 3 (each within the scatter of the next). At a limit, above all of these: compound 4.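

Among these compounds, the first pair here that changes configuration and nothing else gives, in this assay, an at least 1.6-fold higher number from compound 3 to compound 4 (0.21 log units; that floor lies within the scatter). Compound 4 is reported only as a limit, > 5000 nM, so this step is a floor: it shows no change beyond the usual scatter, and its full size cannot be read. Any shift in this pair can come only from the arrangement in space, because no atom or bond changes: the fact that compounds 3 and 4 differ only in the configuration as drawn

Two stereocentres at saturated chain carbons differ together, so the compounds shown leave open whether one of them alone matters, or which one. From the compounds shown here alone, how an amine or a longer chain at either of these carbons would read in this assay also remains open.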